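Notes on the aromatic substituent of the benzyl group

The compounds below may be only part of what the source reports. "The series", "measured", "known", "first", "only" and "open" are said of these compounds alone.

Measured so far:
compound 1 `COC(=O)/C=C/c1cccc(N(Cc2ccc(/C=C/c3ccccc3F)cc2)C(=O)C2CCCCC2)c1`: 64 nM
compound 2 `COC(=O)/C=C/c1cccc(N(Cc2ccccc2)C(=O)C2CCCCC2)c1`: > 1000 nM
compound 3 `COC(=O)/C=C/c1cccc(N(Cc2ccc(C(C)(C)C)cc2)C(=O)C2CCCCC2)c1`: > 1000 nM

In an assay on isolated protein with Bile acid receptor (Homo sapiens) as the target (a lower number here means that less compound is needed, a higher number that more compound is needed for the effect), compound 1 gives 64 nM. For compound 2 the value > 1000 nM is a limit of the assay, not a number. For compound 3 the value > 1000 nM is likewise a limit. Compound 3 thus stands at the weak end of what has been measured, with no number of its own, as does compound 2 (the limit of > 1000 nM in this assay, at which 2 of the 3 values shown sit). Two steps lead to this end: an at least 15-fold higher number from compound 1 to compound 2 (1.19 log units; beyond the scatter), and an at least 15-fold higher number from compound 1 to compound 3 (1.19 log units; beyond the scatter). Between the two weak compounds, a step that the two limits leave unreadable from compound 2 to compound 3.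

The step to compound 4 `CCOC/C=C/c1ccc(CN(C(=O)C2CCCCC2)c2cccc(/C=C/C(=O)OC)c2)cc1` is 3-ethoxyprop-1-en-1-yl in place of tert-butyl on an aromatic carbon. The entering chain shares with the 2-(2-fluorophenyl)ethenyl group of compound 1 a double bond outside aromatic rings, but brings no ring. The bearing steps are an at least 15-fold higher number from compound 1 to compound 3 (1.19 log units; beyond the scatter) and an at least 15-fold higher number from compound 1 to compound 2 (1.19 log units; beyond the scatter); both were large, and both point away from compound 1. A partial return towards compound 1 is expected, but a sizeable chance remains that only a limit is read again. Compound 4 is therefore estimated at 600 nM, between 120 nM and 3000 nM. This means an expected at least 1.6-fold lower number from compound 3 to compound 4 (0.22 log units; that floor lies within the scatter).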

Compound 4, half-maximal effective concentration: 198000 nM
The estimate for compound 4 lay 330-fold (2.52 log units) below the measured number; measured number above the stated range.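

In this assay, for the compounds shown here, ethoxymethyl in place of 2-fluorophenyl on the double-bonded chain gives a 3100-fold higher number from compound 1 to compound 4 (3.49 log units; beyond the scatter), the only step at this position with a number at both ends. A double bond outside aromatic rings at this position is thus not enough: compound 4 keeps it and loses nearly all of the potency of compound 1, so the group at the end of the chain matters greatly. The steps from compound 2 and from compound 3 to compound 4 cannot be read, because those two compounds sit at a limit: the limit of > 1000 nM in this assay, at which 2 of the 4 values shown sit.

Which feature of 2-fluorophenyl matters remains open, as the shown compounds do not separate the ring from its fluorine. Whether plain phenyl, a pyridine ring or a saturated two-carbon link in place of the double bond would hold the potency of compound 1 is also unresolved.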